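A few compounds are considered here, and "the series" means these few. Any claim that something is new, unique, unknown or untested is made for them only; others in the source may bear on it.

In a physicochemical assay for lipophilicity, in phosphate buffer, measured as octanol-water partition, with a stated time of 24 h (on this read-out higher numbers stand for higher lipophilicity and lower numbers for lower lipophilicity), compound 1 `S=C(N/N=C/c1ccc(Oc2ccc3ccccc3c2)cc1)Nc1ccc(Cl)cc1` gives 6.96, the highest of the three numbers in hand. Compound 2 `S=C(N/N=C/c1ccc(Oc2ccc3ccccc3c2)cc1)Nc1ccccc1` gives 6.07, and compound 3 `S=C(N/N=C/c1ccc(Oc2ccc3ccccc3c2)cc1)Nc1ccc(Br)cc1` gives 6.93. The measured steps all concern the halogen on the thiourea-side ring: a number 0.89 log units lower from compound 1 to compound 2 (beyond the scatter), a number 0.03 log units lower from compound 1 to compound 3 (within the scatter), and a number 0.86 log units higher from compound 2 to compound 3 (beyond the scatter). Compound 4 `O=[N+]([O-])c1ccc(Oc2ccc(/C=N/NC(=S)Nc3ccc(Cl)cc3)cc2)cc1` changes a different part of the shared core: 4-nitrophenyl in place of naphthalen-2-yl on an oxygen on an aromatic ring. Going by the values given here, no measured step touches the group on that oxygen, so none bears directly on this change; the halogen steps show only that a single substituent on one ring moves this read-out by a modest amount. Here a fused bicyclic group leaves and a single ring carrying a nitro group enters. Starting from compound 1 at 6.96, compound 4 is expected to read lower, by a number 1.36 log units lower from compound 1 to compound 4 (beyond the scatter). The estimate for compound 4 is 5.6, with a range of 4.9 to 6.3.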

Compound 4, partition coefficient: 5.52
Estimate against measurement, compound 4: 0.08 log units above; low and high end bracket the measured number.
By their numbers in this assay, from the lowest: compound 4; then compound 2; then compounds 3 and 1 (each within the scatter of the next).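

Working notes: the group on the oxygen on an aromatic ring moves this read-out as well, and by more than the halogen change does. In this assay the replacement of naphthalen-2-yl by 4-nitrophenyl gives a number 1.44 log units lower from compound 1 to compound 4 (beyond the scatter), a larger step than a number 0.89 log units lower from compound 1 to compound 2 (beyond the scatter). The swap removes one six-membered aromatic ring and brings in a nitro group at once, so this single step does not separate the two changes, and nothing available accounts for its size.

Open, going by these compounds, is how a plain phenyl, or a phenyl carrying an amine or a carboxylic acid, would read on that oxygen. Also open, on these data alone, is whether removing the chloro group from compound 4 would give a step of similar size to the one seen with naphthalen-2-yl in place.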